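The source may report more compounds than this note shows. Statements on the series, on what has been measured and on what is new or still open speak of the compounds shown alone.

Measured in a physicochemical assay for solubility, read by spectrophotometry, in phosphate buffer, measured as kinetic solubility, with a stated time of 18 h, at pH 7.4; on this read-out lower numbers stand for lower solubility and higher numbers for higher solubility:
- compound 1 `O=C(O)COc1cc(Cl)c(C(=O)Nc2cccc(-c3nc4ccccc4s3)c2)cc1[N+](=O)[O-]`: 6700 nM
- compound 2 `O=C(Nc1ccc(O)c(-c2nc3ccccc3s2)c1)c1cc([N+](=O)[O-])ccc1Cl`: 23 nM
- compound 3 `Cc1cc(NC(=O)c2cc([N+](=O)[O-])ccc2Cl)cc(-c2nc3ccccc3s2)c1O`: 430 nM

Of these three, compound 2 has the lowest number, 23 nM. Its closest neighbour is compound 3 at 430 nM, and compound 1 lies furthest away at 6700 nM.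

The next compound to be read is compound 4 `COc1ccc(NC(=O)c2cc([N+](=O)[O-])ccc2Cl)cc1-c1nc2ccccc2s1`. It departs from compound 2 by one change: methyl in place of hydrogen on an oxygen on an aromatic ring. This is methyl in place of hydrogen on an oxygen on an aromatic ring, or hydroxy to methoxy.

Within the data shown here, only one measured step bears on this change: a 19-fold higher number from compound 2 to compound 3 (1.27 log units; beyond the scatter). That step also brings in a methyl, but it replaces hydrogen on an aromatic carbon rather than on an oxygen. Among the measured compounds shown here, no step at the oxygen has been measured, so it serves only as a loose guide to direction and size. Compound 2 also offers little precedent for a fall, since both other compounds read higher. A rise is therefore expected in this assay, though a smaller one than the step to compound 3, and it may not clear the scatter by much.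

The expected change is a 3.9-fold higher number from compound 2 to compound 4 (0.59 log units; beyond the scatter). For compound 4 the estimated value is 90 nM, with an expected range of 20 nM to 450 nM.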

Compound 4, solubility: 260 nM
Compound 4: middle estimate off by 2.9-fold (0.46 log units), on the low side, and the stated range covers the measured number.
By their numbers in this assay, from the lowest: compound 2; then compounds 4 and 3 (each within the scatter of the next); then compound 1.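

In this assay, the change at the oxygen on an aromatic ring now has a direct reading, (an 11-fold higher number from compound 2 to compound 4 (1.05 log units; beyond the scatter)), and hydroxy to methoxy proves a large step rather than one that barely clears the scatter. Among these compounds, until now the only methyl step in hand was the one on an aromatic carbon (a 19-fold higher number from compound 2 to compound 3 (1.27 log units; beyond the scatter)), so this result adds a second large step from compound 2 in the same direction, with the methyl standing in a different place. For this pair, replacing hydrogen with methyl on the oxygen raises the number, but no supporting measurement is available to account for the rise.

Only the single methyl on this oxygen is shown, so it remains open whether an ethyl or a longer chain there would give a step of similar size or direction. Going by these compounds, it is equally open how compound 2 would compare with an amine or a fluorine in place of the hydroxy, and whether the step from hydroxy to methoxy would hold on a different core.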